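The compounds below may be only part of what the source reports. "The series", "measured", "known", "first", "only" and "open" are said of these compounds alone.

Compound 1 `O=C1C(Nc2ccc(I)cc2)=CC(=O)c2c1nc1n2[C@H]2OC[C@@H](O)[C@H]2OC1`: 2150 nM
Compound 2 `COc1ccccc1NC1=CC(=O)c2c(nc3n2[C@H]2OC[C@@H](O)[C@H]2OC3)C1=O`: 1670 nM
Compound 3 `O=C1C(N2CCCCC2)=CC(=O)c2c1nc1n2[C@H]2OC[C@@H](O)[C@H]2OC1`: > 4000 nM

All three results come from a functional assay on MGC-803 cells (Homo sapiens) for inhibition, read by sulforhodamine B assay; a lower number here means a stronger inhibitor, a higher number a weaker inhibitor. Compound 3 has no number of its own, since its > 4000 nM is a limit of the assay. Compound 4 `COc1ccc(NC2=CC(=O)c3c(nc4n3[C@H]3OC[C@@H](O)[C@H]3OC4)C2=O)cc1` shares the core of compound 3 and differs from it in a single group on a double-bonded ring carbon, where (4-methoxyphenyl)amino stands in place of piperidin-1-yl: (4-methoxyphenyl)amino in place of piperidin-1-yl on a double-bonded ring carbon.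

Two measured steps make the same kind of exchange in the opposite direction, from a substituted phenylamino group to piperidin-1-yl: an at least 1.8-fold higher number from compound 1 to compound 3 (0.26 log units; that floor lies within the scatter), and an at least 2.3-fold higher number from compound 2 to compound 3 (0.37 log units; beyond the scatter). A third step bears on the choice of phenyl group, and the two phenylamino compounds lie within the scatter of each other: a 1.3-fold lower number from compound 1 to compound 2 (0.11 log units; within the scatter). Compound 4 also carries a substituted phenylamino group, so it is expected to lie close to compound 1 and compound 2 in this assay. The size of the change is therefore expected to be modest, towards a lower number: an at least 2.1-fold lower number from compound 3 to compound 4 (0.32 log units; beyond the scatter). For compound 4 the estimated value is 1900 nM, with an expected range from 950 nM to 3800 nM.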

Compound 4, half-maximal inhibitory concentration: 2150 nM
Compound 4: middle estimate off by 1.1-fold (0.05 log units), on the low side; the range from low to high includes it.
By their numbers in this assay, from the lowest: compounds 2, 1 and 4 (each within the scatter of the next). At a limit, above all of these: compound 3.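

In this assay, 2-methoxyphenyl gives way to 4-methoxyphenyl on the amine nitrogen with a 1.3-fold higher number from compound 2 to compound 4 (0.11 log units; within the scatter), and methoxy in place of iodo on the aromatic carbon gives no change at the digits printed from compound 1 to compound 4 (within the scatter), so the three phenylamino compounds now stand together with no order among them. Compound 3 has only a limit in this assay, > 4000 nM, and not a number. The exchange of piperidin-1-yl for (4-methoxyphenyl)amino on the double-bonded ring carbon gives an at least 1.8-fold lower number from compound 3 to compound 4 (0.26 log units; that floor lies within the scatter), which adds a third phenylamino comparison on that carbon but leaves the true size of the gap unknown, with the floor resting on a single value: the limit of > 4000 nM in this assay, at which 1 of the 4 values shown sits.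

The compounds shown leave open whether a phenylamino group carrying a carboxylic acid or a dimethylamino group on its aromatic ring would still stand with compounds 1, 2 and 4. They also leave open whether a benzylamino group or an open-chain amine such as diethylamino on the same carbon would stand with those compounds or with compound 3.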